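Moving a chlorine around the ring: cytotoxicity of compound 3

The source may report more compounds than this note shows. Statements on the series, on what has been measured and on what is new or still open speak of the compounds shown alone.

Compound 1, `Oc1ccc(-c2cc(-c3cccc(Cl)c3)nc(-c3ccccn3)c2)cc1`: in an ADME assay on HEK293 cells (Homo sapiens) for cytotoxicity, read by CCK-8 assay and cell counting, with a stated time of 2 days (on this read-out lower numbers stand for stronger inhibition and higher numbers for weaker inhibition), compound 1 gives 25400 nM.
Compound 2, `Oc1ccc(-c2cc(-c3ccc(Cl)cc3)nc(-c3ccco3)c2)cc1`: in this assay compound 2 gives 5720 nM.

Of these two numbers, compound 2 has the lower one; the gap to compound 1 lies beyond the usual scatter, but the two compounds differ in more than one place, so no single step can be read from them. Compound 3, `Oc1ccc(-c2cc(-c3cccc(Cl)c3)nc(-c3ccco3)c2)cc1`, is made from compound 2 by one change: 3-chlorophenyl in place of 4-chlorophenyl on an aromatic carbon. Among the compounds with values here, with no measured step of this kind available, the expected change from compound 2 to compound 3 in this assay is a 1.4-fold higher number from compound 2 to compound 3 (0.15 log units; within the scatter), not clearly beyond the scatter. Compound 3 is therefore estimated at 8000 nM, between 3000 nM and 22000 nM.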

Compound 3, half-maximal inhibitory concentration: 2880 nM
Estimate against measurement, compound 3: 2.8-fold (0.44 log units) above; the measured number lies below the stated range.
By their numbers in this assay, from the lowest: compounds 3 and 2 (each within the scatter of the next); then compound 1.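

In this assay, 3-chlorophenyl in place of 4-chlorophenyl gives a 2.0-fold lower number from compound 2 to compound 3 (0.30 log units; within the scatter), which is within the scatter, so these numbers do not tell the two chlorophenyl groups apart at this position. Within the data shown here, the other single change counts for more: furan-2-yl in place of pyridin-2-y1 gives an 8.8-fold lower number from compound 1 to compound 3 (0.95 log units; beyond the scatter), the first step here that clears the scatter. No measurement at hand explains either step.

The compounds shown leave open how a methoxy group or an amine in place of the chlorine would read. They also leave open whether a plain phenyl would match the chlorophenyl compounds.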